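A few compounds are considered here, and "the series" means these few. Any claim that something is new, unique, unknown or untested is made for them only; others in the source may bear on it.

Series notes. Compound 1 `O=c1c(Br)c(C(F)(F)F)[nH]c2c(Br)cccc12`, compound 2 `FC(F)(F)c1nc2c(Br)cccc2c(Cl)c1Br` and compound 3 `COc1ccc(-c2c(C(F)(F)F)nc3c(-c4ccc(OC)cc4)cccc3c2-c2ccc(OC)cc2)cc1` have been run in an assay for inhibition of ectonucleoside triphosphate diphosphohydrolase 1 (Homo sapiens), read by malachite green, with a stated time of 10 min; on this read-out higher numbers stand for weaker inhibition and lower numbers for stronger inhibition. In this assay compound 1 returns only a limit, > 300000 nM. Compound 2 also returns only a limit, > 300000 nM. Compound 3 again returns only a limit, > 300000 nM. Among the measured compounds shown here, all three therefore sit at the limit of > 300000 nM in this assay, at which 3 of the 3 values shown sit, so compound 2 is not separated from the others, and no step between measured compounds can be sized or given a direction. Compound 4 `N#Cc1cccc(-c2cccc3c(Cl)c(Br)c(C(F)(F)F)nc23)c1` is next to be tested in this assay. It differs from compound 2 by 3-cyanophenyl in place of bromo on an aromatic carbon. With every measured value a limit, no direction for this change can be drawn from the series; the step from compound 2 to compound 4 is expected as an at least 1.5-fold lower number from compound 2 to compound 4 (0.17 log units; that floor lies within the scatter). Compound 4 is estimated at 200000 nM, in the range 30000 nM to 300000 nM.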

Compound 4, half-maximal inhibitory concentration: > 300000 nM
Compound 4: no number, only a limit; the forecaster's own chance of this, stated with the estimate: 65%; at least 1.5-fold (0.17 log units) between middle value and limit.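

No step can be read between compound 2 and compound 4, as both return only a limit: the limit of > 300000 nM in this assay, at which 4 of the 4 values shown sit. The compounds shown leave open which change to the shared core, if any, gives a measurable inhibition value.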